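Removing the methoxy from compound 1: the unsubstituted analogue

A few compounds are considered here, and "the series" means these few. Any claim that something is new, unique, unknown or untested is made for them only; others in the source may bear on it.

The series shares one core; compound 1 `COc1ccc(-n2nc(-c3ccc4ccccc4c3)nc2N2C(=O)COC23C=CC(=O)C=C3)cc1` carries a methoxy on an aromatic carbon. Among the compounds with values here, in a functional assay on A549 cells (Homo sapiens) for antiproliferative activity, with a stated time of 5 days (on this read-out higher numbers stand for weaker inhibition and lower numbers for stronger inhibition), compound 1 gives 260 nM, the highest of the three numbers measured so far. Compound 2 `Cc1ccc(-n2nc(-c3ccc4ccccc4c3)nc2N2C(=O)COC23C=CC(=O)C=C3)cc1` gives 110 nM, and compound 3 `Cc1ccccc1-n1nc(-c2cccc3ccccc23)nc1N1C(=O)COC12C=CC(=O)C=C2` gives 130 nM; the gap between compound 1 and compound 3 lies within the scatter, so no order can be read from those two.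

Compound 4 `O=C1C=CC2(C=C1)OCC(=O)N2c1nc(-c2ccc3ccccc3c2)nn1-c1ccccc1` is not yet measured. Against compound 1 the change is hydrogen in place of methoxy on an aromatic carbon.

Within the data shown here, one measured step bears on this. Putting methyl in place of methoxy on an aromatic carbon gave a 2.4-fold lower number from compound 1 to compound 2 (0.37 log units; beyond the scatter), a modest gain just beyond the scatter. Compound 4 takes the methoxy away without putting any group in its place, so that step is the closest guide, though not the same change. Either a modest lowering of the number or no movement beyond the scatter seems plausible; a large shift in either direction has no support among the measured compounds.

Compound 4 is therefore expected to give 180 nM in this assay, between 80 nM and 400 nM, which means an estimated 1.4-fold lower number from compound 1 to compound 4 (0.16 log units; within the scatter).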

Compound 4, half-maximal inhibitory concentration: 140 nM
Estimate against measurement, compound 4: 1.3-fold (0.11 log units) above; the range from low to high includes it.
By their numbers in this assay, from the lowest: compounds 2, 3, 4 and 1 (each within the scatter of the next, the first and the last beyond it).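

In this assay, cutting 4-methoxyphenyl back to phenyl gives a 1.9-fold lower number from compound 1 to compound 4 (0.27 log units; within the scatter) and so stays within the scatter, which means that with the group gone altogether, compound 4 cannot be separated from compound 1. Hydrogen and methyl at this place cannot be separated either, with a 1.3-fold higher number from compound 2 to compound 4 (0.10 log units; within the scatter) also within the scatter, so the earlier step of a 2.4-fold lower number from compound 1 to compound 2 (0.37 log units; beyond the scatter) does not show that a methyl group is needed at this carbon, and compound 4 sits within the scatter of both neighbours even though those two lie just beyond it from each other. Nothing measured alongside these numbers speaks to what lies behind them.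

Going by these compounds, these three compounds span a narrow range of small groups at this carbon, so it remains open whether a chlorine atom, an amine, a carboxylic acid or a longer chain such as butoxy would move the number beyond the scatter in either direction. On these data alone, whether hydrogen, methyl and methoxy would stay this close on a different aryl group of the shared core also remains open.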